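Swapping an amine substituent for an amide in a melanocortin ligand

The compounds below may be only part of what the source reports. "The series", "measured", "known", "first", "only" and "open" are said of these compounds alone.

Of the compounds shown here, two built on the same core have been measured so far. Compound 1 `CC(C)C[C@H](N)c1cc(C(F)(F)F)ccc1N1CCN(C(=O)C2COCC2c2ccc(Cl)cc2)CC1` carries a free amine and gives 280 nM in an assay on HEK293 cells for displacement of a labelled ligand from Melanocortin receptor 4 (Homo sapiens); on this read-out lower numbers stand for stronger inhibition and higher numbers for weaker inhibition. Compound 2 `CC(C)C[C@H](NCCN(C)C)c1cc(C(F)(F)F)ccc1N1CCN(C(=O)[C@H]2CS(=O)(=O)C[C@@H]2c2ccc(Cl)cc2)CC1` instead carries a 2-(dimethylamino)ethyl group on that amine nitrogen, and in this assay compound 2 gives 170 nM. Of the two numbers this is the lower one, but compound 1 sits within the usual scatter of it, so the two values show essentially the same strength of binding.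

Compound 3 `CN[C@H](C)C(=O)N[C@@H](CC(C)C)c1cc(C(F)(F)F)ccc1N1CCN(C(=O)[C@H]2CS(=O)(=O)C[C@@H]2c2ccc(Cl)cc2)CC1` keeps the sulfone-bearing core of compound 2 and changes only the group on the amine nitrogen: (1-(methylamino)ethyl)carbonyl in place of 2-(dimethylamino)ethyl on an amine nitrogen. Among the compounds with values here, no measured pair shows this exact change, so its effect is not known from the data. The expectation is for a step from compound 2 to compound 3 that stays close to the scatter, leaning if anything towards a lower number, a 1.5-fold lower number from compound 2 to compound 3 (0.19 log units; within the scatter). On that basis compound 3 is estimated to give 110 nM in this assay, with a likely range from 35 nM to 350 nM.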

Compound 3, inhibition constant: 100 nM
The estimate for compound 3 lay 1.1-fold (0.04 log units) above the measured number; measured number inside the range.
By their numbers in this assay, from the lowest: compounds 3, 2 and 1 (each within the scatter of the next, the first and the last beyond it).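

Within the data shown here, this is the first pair of compounds that differ in one place only, so it gives a direct reading of the substituent on the amine nitrogen: in this assay, putting (1-(methylamino)ethyl)carbonyl in place of 2-(dimethylamino)ethyl gives a 1.7-fold lower number from compound 2 to compound 3 (0.23 log units; within the scatter) and leaves binding essentially unchanged. The swap turns that amine nitrogen into an amide and brings in a carbonyl, a hydrogen-bond donor and a defined stereocentre, yet the two numbers stay within the usual scatter, so on this core the position accepts both of these rather different groups. No measurement at hand explains why the two groups read alike.

The compounds shown leave open whether the amine at the far end of the chain matters, which an acetyl group, an amide with no second nitrogen, would test, and whether a longer chain ending in a dimethylamino group would read the same. Also open, from the compounds shown here alone, are the role of the defined stereocentre, which the opposite stereoisomer of the (1-(methylamino)ethyl)carbonyl group would address, and how a free amine would read on the core of compound 2.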